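The source may hold more compounds than are shown below. What is called first, only, known or untested is meant among the compounds shown, and "the series" means these compounds.

Working notes on the series. Compound 1 `CC(=O)c1cc(C(=O)c2ccccc2)c(=O)[nH]c1C` and compound 2 `O=C1CCCc2[nH]c(=O)c(C(=O)c3ccccc3)cc21` carry different cores; the difference between the two cores is not broken down here. In an assay on CHO cells for displacement of a labelled ligand from adenosine receptor A3 (Homo sapiens), tested at 10 uM (a lower number here means less inhibition, a higher number more inhibition at the concentration tested (going by the name of the read-out)), compound 1 gives 0%, and compound 2 gives 0%, the two values lying within the usual scatter of each other. Compound 3 `CC(=O)c1cc(C(=O)C(C)(C)C)c(=O)[nH]c1C` differs from compound 1 by tert-butyl in place of phenyl on a carbonyl carbon; in this assay compound 3 gives 13%, a step of a number 13 percentage points higher from compound 1 to compound 3 (beyond the scatter). Compound 4 `CC(C)(C)C(=O)c1cc2c([nH]c1=O)CCCC2=O` differs from compound 2 by tert-butyl in place of phenyl on a carbonyl carbon, the same change at the same kind of place, here made on the core of compound 2. Among the measured compounds shown here, for compound 4 a step of a number 13 percentage points higher from compound 2 to compound 4 (beyond the scatter) is expected in this assay, set beside the one step seen, which rests on compound 1 moving to compound 3 by a number 13 percentage points higher from compound 1 to compound 3 (beyond the scatter). Compound 4 is therefore estimated at 13%, with a range from 0% to 27%.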

Compound 4, a percentage reported as inhibition, at one concentration (the size of the read-out at that concentration, not a potency): 0%
Compound 4: middle estimate off by 13 percentage points, on the high side; the range from low to high includes it.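

Tert-butyl in place of phenyl on a carbonyl carbon gives, in this assay, no change at the digits printed from compound 2 to compound 4 (within the scatter). Set beside the step on the core of compound 1, the two steps cannot be told apart: the same change on two cores in this assay, a number 13 percentage points higher (beyond the scatter) from compound 1 to compound 3 and no change at the digits printed (within the scatter) from compound 2 to compound 4, 13 percentage points apart, within the scatter of two such steps. With one pair per core, at a single concentration, this shows neither that the change carries over between the two cores nor that the core of compound 2 cancels it.

Still open, on these data alone, is whether a different group on the same carbonyl carbon, such as an amine or a longer chain, would move the read-out on either core. Also open, as far as these compounds go, is whether a carboxylic acid there would behave alike on the two cores.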